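The source may hold more compounds than are shown below. What is called first, only, known or untested is meant among the compounds shown, and "the series" means these compounds.

Within the data shown here, in a functional assay on DU-145 cells (Homo sapiens), read by sulforhodamine B assay, with a stated time of 5 days (on this read-out lower numbers stand for stronger inhibition of growth and higher numbers for weaker inhibition of growth), compound 1 `OC[C@H]1O[C@@H](n2cc(F)c3c(-c4ccccc4)ncnc32)[C@H](O)[C@@H]1O` gives 580 nM, the highest of the three numbers so far. Compound 4 `OC[C@H]1O[C@@H](n2cc(F)c3c(-c4ccsc4)ncnc32)[C@H](O)[C@@H]1O` keeps the shared core and changes one group: thiophen-3-yl in place of phenyl on an aromatic carbon. Two measured changes replace that same phenyl. Compound 2 `OC[C@H]1O[C@@H](n2cc(F)c3c(-c4ccc[nH]4)ncnc32)[C@H](O)[C@@H]1O`, with 1H-pyrrol-2-yl, gives 9 nM, and compound 3 `OC[C@H]1O[C@@H](n2cc(F)c3c(-c4ccoc4)ncnc32)[C@H](O)[C@@H]1O`, with furan-3-yl, gives 5 nM. Both steps are large: a 64-fold lower number from compound 1 to compound 2 (1.81 log units; beyond the scatter), and a 120-fold lower number from compound 1 to compound 3 (2.06 log units; beyond the scatter). The gap between these two results stays within the scatter: a 1.8-fold lower number from compound 2 to compound 3 (0.26 log units; within the scatter). A similarly large drop is therefore expected in this assay, and the expected step is a 58-fold lower number from compound 1 to compound 4 (1.76 log units; beyond the scatter). For compound 4 the estimated value is 10 nM, with an expected range from 3 nM to 35 nM.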

Compound 4, concentration for 50% growth inhibition: 66 nM
Beside the measured number, compound 4's estimate is 6.6-fold (0.82 log units) below it, and the stated range ends below it.
By their numbers in this assay, from the lowest: compounds 3 and 2 (each within the scatter of the next); then compound 4; then compound 1.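

In this assay, the five-membered rings at this position do not all act alike: thiophen-3-yl gives an 8.8-fold lower number from compound 1 to compound 4 (0.94 log units; beyond the scatter), yet compared with the other two rings there is a 13-fold higher number from compound 3 to compound 4 (1.12 log units; beyond the scatter) and a 7.3-fold higher number from compound 2 to compound 4 (0.87 log units; beyond the scatter). Thus, changing furan-3-yl to thiophen-3-yl, which swaps the ring's oxygen for sulfur, is enough to move the number beyond the scatter. Nothing available here explains this difference. On these data alone, what a pyridin-3-yl ring or an amine would give at this position remains open.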